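Removing One Chlorine: What the Cell Growth Numbers Suggest

A few compounds are considered here, and "the series" means these few. Any claim that something is new, unique, unknown or untested is made for them only; others in the source may bear on it.

Measured so far:
compound 1, `ClCc1ccc(Cn2cnc3c(Cl)ncnc32)cc1`, 21400 nM
compound 2, `ClCc1ccccc1Cn1cnc2c(Cl)nc(Cl)nc21`, 1470 nM

These values come from a functional assay on BT-549 cells (Homo sapiens) for cytotoxicity, read by sulforhodamine B assay, with a stated time of 48 h; a lower number here means a stronger inhibitor of growth, a higher number a weaker inhibitor of growth. Among the measured compounds shown here, of the two numbers known, compound 2 has the lowest; its nearest neighbour, compound 1, sits well beyond the scatter with a much higher value, so compound 2 is the stronger growth inhibitor of the pair.

The next step keeps the shared core and the ortho-substituted side chain of compound 2 but changes one substituent on the core: hydrogen in place of chloro on an aromatic carbon. The result is compound 3, `ClCc1ccccc1Cn1cnc2c(Cl)ncnc21`, not yet measured.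

Only compound 1 offers guidance here: it also carries a single chloro on the core and gives 21400 nM. On that basis the step is expected to raise the number, with a 4.1-fold higher number from compound 2 to compound 3 (0.61 log units; beyond the scatter) as the estimated size. Compound 3 is therefore expected to give about 6000 nM, in a range from 1500 nM to 25000 nM.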

Compound 3, concentration for total growth inhibition: 5490 nM
For compound 3 the middle estimate is 1.1-fold (0.04 log units) above the measured one; the measured number falls inside the stated range.
By their numbers in this assay, from the lowest: compound 2; then compound 3; then compound 1.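

In this assay, replacing the chloro that sits between two ring nitrogen atoms with hydrogen gives a 3.7-fold higher number from compound 2 to compound 3 (0.57 log units; beyond the scatter) and counts as a modest step. Among the compounds shown here, this is the first direct reading of this position, as the other chloro on the core and the side chain stay the same, so the shift belongs to this one change. It shows that the chloro at this position goes with the lower number in this pair, but no measurement here explains why.

Going by these compounds, whether an amine, a methoxy group or a fluoro group at this position would give a lower or higher number than chloro or hydrogen remains open. On these data alone, how the same swap would read with the side chain of compound 1 also stays open.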